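Replacing the methylpyridinyl with bromo: lipophilicity outlook

The compounds below may be only part of what the source reports. "The series", "measured", "known", "first", "only" and "open" are said of these compounds alone.

Measured compounds:
- compound 1, `CC[C@@H](Nc1c(C#N)c(-c2ccc(-c3ncccc3C)cc2)nc2cnccc12)C(N)=O`: 2
- compound 2, `CC[C@@H](Nc1c(C#N)c(-c2ccc(-c3ccc(F)cc3)cc2)nc2cnccc12)C(N)=O`: 2.7
- compound 3, `CN(CC(N)=O)c1c(C#N)c(-c2ccc(Br)cc2)nc2cnccc12`: 2.1

In a physicochemical assay for lipophilicity, read by HPLC, at pH 7.5 (a lower number here means a more polar compound, a higher number a more lipophilic compound), compound 1 gives 2, the lowest of the three numbers. Compound 3 sits nearest to it, within the scatter, while compound 2 stands furthest away, beyond the scatter. Going by the values given here, the one measured step that changes only one place is a number 0.70 log units higher from compound 1 to compound 2 (beyond the scatter).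

The unmeasured compound 4, `CC[C@@H](Nc1c(C#N)c(-c2ccc(Br)cc2)nc2cnccc12)C(N)=O`, departs from compound 1 by bromo in place of 3-methylpyridin-2-yl on an aromatic carbon.

The step from compound 1 to compound 2 bears on this change, since both swap the 3-methylpyridin-2-yl for a different group at the same aromatic carbon; that step was a modest rise, beyond the scatter. Compound 3 also carries bromo at that position, and with a different side chain it gives 2.1, close to compound 1. Weighing the rise seen in compound 2 against the number of compound 3, a modest upward step is expected for compound 4, a number 0.60 log units higher from compound 1 to compound 4 (beyond the scatter), because the step of a number 0.70 log units higher from compound 1 to compound 2 (beyond the scatter) shows what the loss of the 3-methylpyridin-2-yl did in this assay. Compound 4 is therefore estimated at 2.6, expected to fall between 2.1 and 3.1.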

Compound 4, distribution coefficient: 2.2
Beside the measured number, compound 4's estimate is 0.40 log units above it; low and high end bracket the measured number.
By their numbers in this assay, from the lowest: compounds 1, 3 and 4 (each within the scatter of the next); then compound 2.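

In this assay bromo in place of 3-methylpyridin-2-yl, on an aromatic carbon para to a large group, comes to a number 0.20 log units higher from compound 1 to compound 4 (within the scatter) and so leaves the read-out within the scatter, even though a single bromine takes the place of an aromatic ring. At this same position the bromo and 4-fluorophenyl groups stand apart (a number 0.50 log units lower from compound 2 to compound 4 (beyond the scatter)), which shows that the earlier step seen with the 4-fluorophenyl does not carry over to every replacement of the 3-methylpyridin-2-yl. With bromo in place, the other varied position adds a second reading: (1-carbamoylpropyl)amino in place of (carbamoylmethyl)(methyl)amino gives a number 0.10 log units higher from compound 3 to compound 4 (within the scatter), which also lies within the scatter.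

Still open, as far as these compounds go, is how other groups on this aromatic carbon would read against these three, for example chloro, a carboxylic acid or a morpholine ring. Nothing among the data shown accounts for why the 4-fluorophenyl compound stands apart from the bromo and 3-methylpyridin-2-yl compounds.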